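Longer side chain on the quinone core of compound 1

The source may report more compounds than this note shows. Statements on the series, on what has been measured and on what is new or still open speak of the compounds shown alone.

Of the compounds shown here, three have been measured in a functional assay on L1210 cells (Mus musculus) for cytotoxicity; on this read-out lower numbers stand for an effect already at smaller amounts and higher numbers for an effect only at larger amounts of compound. Compound 1 `CCCCCC(O)c1cc(OC)c2c(c1OC)C(=O)C=CC2=O` gives 0.066 ug/mL in this assay, the lowest of the three numbers. Going by the values given here, compound 2 `CCCCCC(O)C1=CC(=O)c2c(OC)ccc(OC)c2C1=O` gives 0.378 ug/mL in this assay, and compound 3 `CCCCC(O)C1=CC(=O)c2c(OC)ccc(OC)c2C1=O` gives 0.412 ug/mL in this assay; both stand beyond the scatter from compound 1, while the single step that shortens the chain, a 1.1-fold higher number from compound 2 to compound 3 (0.04 log units; within the scatter), stays within the scatter. The account now follows the step to compound 4 `CCCCCCCC(O)c1cc(OC)c2c(c1OC)C(=O)C=CC2=O`, which differs from compound 1 by ethyl in place of hydrogen on a saturated chain carbon, six bonds along the chain from an aromatic carbon and an oxygen on a saturated carbon. Among the compounds with values here, the only measured step that touches the length of this chain is the one between compounds 2 and 3, and it is small; it was run on a core that differs from the core of compound 1, so it informs the expectation only loosely. On that basis the step from compound 1 to compound 4 is expected to be a 1.1-fold higher number from compound 1 to compound 4 (0.03 log units; within the scatter), no change beyond the scatter. For compound 4 the estimated value in this assay is 0.07 ug/mL, with a range from 0.03 ug/mL to 0.17 ug/mL.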

Compound 4, concentration for half-maximal effect: 0.274 ug/mL
For compound 4 the middle estimate is 3.9-fold (0.59 log units) below the measured one; measured number outside the range, above it.
By their numbers in this assay, from the lowest: compound 1; then compounds 4, 2 and 3 (each within the scatter of the next).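

On the core of compound 1, the length of the chain matters in this assay: ethyl in place of hydrogen on a saturated chain carbon, six bonds along the chain from an aromatic carbon and an oxygen on a saturated carbon, gives a step beyond the scatter (a 4.2-fold higher number from compound 1 to compound 4 (0.62 log units; beyond the scatter)). Going by these compounds alone, the only earlier step that touched chain length, on a different core, stayed within the scatter (a 1.1-fold higher number from compound 2 to compound 3 (0.04 log units; within the scatter)), so that small step does not carry over to this core. No measurement at hand explains why this lengthening raises the number.

On these data alone, with a single lengthening on this core, it remains open whether a still longer chain would move the number further in the same direction or a shorter chain would move it the other way. As far as these compounds go, it also remains open how a chain carrying an amine or a carboxylic acid would behave, and whether the same ethyl change would have a comparable effect on the core of compound 2.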